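The source may hold more compounds than are shown below. What is called first, only, known or untested is meant among the compounds shown, and "the series" means these compounds.

Compound 1 `CCc1nnc(SCC(=O)c2ccc(Cl)cc2)n1N1C(=O)c2ccccc2C1=O` and compound 2 `CCc1nnc(SCC(=O)c2ccc(C)cc2)n1N1C(=O)c2ccccc2C1=O` share a core and differ by methyl in place of chloro on an aromatic carbon. In a functional assay on A549 cells (Homo sapiens) for cytotoxicity, read by MTT assay, with a stated time of 48 h (a lower number here means a stronger inhibitor, a higher number a weaker inhibitor), compound 1 gives > 200000 nM, which is a limit of the assay rather than a number. In this assay compound 2 gives > 200000 nM, also a limit. Because both values sit at the limit of > 200000 nM in this assay, at which 2 of the 3 values shown sit, the step that the two limits leave unreadable from compound 1 to compound 2 cannot be read in either direction. Going by the values given here, compound 3 `COc1cc(-c2nnc(SCC(=O)c3ccc(Cl)cc3)n2N2C(=O)c3ccccc3C2=O)cc(OC)c1OC` differs from compound 1 by 3,4,5-trimethoxyphenyl in place of ethyl on an aromatic carbon; in this assay compound 3 gives 9030 nM, the only plain number among the three measured compounds, and the step of an at least 22-fold lower number from compound 1 to compound 3 (1.34 log units; beyond the scatter) is therefore the one readable step in the set.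

Compound 4 `COc1cc(-c2nnc(SCC(=O)c3ccc(C)cc3)n2N2C(=O)c3ccccc3C2=O)cc(OC)c1OC` differs from compound 3 by methyl in place of chloro on an aromatic carbon. Among the compounds with values here, this is the same change as the one from compound 1 to compound 2, carried over onto the core of compound 3, and the place around it reads the same in both cases. Within the data shown here, the one time the change was made among measured compounds, both ends were limits, so its size is unknown from these data; what is known is that the swapped group is small as counted above. The expected step of a 1.3-fold higher number from compound 3 to compound 4 (0.12 log units; within the scatter) is accordingly small, resting on compound 3 at 9030 nM as the anchor. Compound 4 is expected to give about 12000 nM in this assay. The expected range for compound 4 runs from 4000 nM to 40000 nM.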

Compound 4, half-maximal inhibitory concentration: 6760 nM
The estimate for compound 4 lay 1.8-fold (0.25 log units) above the measured number; the range from low to high includes it.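

In this assay, going by these compounds, methyl in place of chloro gives a 1.3-fold lower number from compound 3 to compound 4 (0.13 log units; within the scatter), and the same swap on the core with ethyl cannot be read, so how this swap carries from one core to the other remains untested. The other change, 3,4,5-trimethoxyphenyl in place of ethyl, gives an at least 29-fold lower number from compound 2 to compound 4 (1.47 log units; beyond the scatter), and it can now be set beside its counterpart on the chloro compounds, with a large step towards a lower number on both cores: the same change on two cores in this assay, an at least 22-fold lower number (1.34 log units; beyond the scatter) from compound 1 to compound 3 and an at least 29-fold lower number (1.47 log units; beyond the scatter) from compound 2 to compound 4; the limit leaves it open whether they differ. This shows that the change carried over in direction and was large on both the 4-chlorophenyl and the 4-methylphenyl compounds, but it does not show that the step has the same size on each, and two pairs are too few to call it a general rule for the series.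

The compounds shown leave open which part of the 3,4,5-trimethoxyphenyl group goes with the lower numbers, a question that a plain phenyl or a longer chain in place of ethyl could help to answer. They also leave open what a carboxylic acid or an amine in place of chloro or methyl would do on the core of compound 3.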